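The compounds below may be only part of what the source reports. "The series", "measured", "known", "first", "only" and "open" are said of these compounds alone.

Among the compounds with values here, only two compounds with the shared core have been measured so far, compound 1 (`CCOC(=O)c1oc2ccccc2c1C`) and compound 2 (`CCOC(=O)c1oc2ccc(C)cc2c1C`). Within the data shown here, in a physicochemical assay for solubility, read by nephelometry, in phosphate buffer, measured as kinetic solubility, at pH 7.4 (on this read-out higher numbers stand for higher solubility and lower numbers for lower solubility), compound 1 gives 200000 nM and compound 2 gives 200000 nM, so compound 2 stands level with compound 1, its only measured neighbour. The next compound, compound 3 (`CCOC(=O)c1oc2ccc(Cl)cc2c1C`), keeps the core of compound 2 and makes a single swap: chloro in place of methyl on an aromatic carbon. Among the measured compounds shown here, one measured step bears on this swap, methyl in place of hydrogen on an aromatic carbon, no change at the digits printed from compound 1 to compound 2 (within the scatter). For the measured compounds named here, that step is only a partial guide, since no compound carrying chloro has been measured yet. With a single step of this size, and compound 2 at 200000 nM, no shift beyond the scatter is expected in this assay, and there is no basis for expecting either direction. The step expected is no change at the digits printed from compound 2 to compound 3 (within the scatter). For compound 3 the estimated value is 200000 nM, with an expected range from 100000 nM to 220000 nM.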

Compound 3, solubility: 200000 nM
Estimate against measurement, compound 3: no gap at the digits printed; the range from low to high includes it.
By their numbers in this assay, from the lowest: compounds 1, 2 and 3 (each within the scatter of the next).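

In this assay, the aromatic carbon that carries methyl in compound 2 carries chloro in compound 3, and this swap gives (no change at the digits printed from compound 2 to compound 3 (within the scatter)), so at this position the two groups cannot be told apart on this read-out. The earlier compounds shown here compared only hydrogen with methyl, whereas chloro in place of hydrogen now gives (no change at the digits printed from compound 1 to compound 3 (within the scatter)), which means that three different substituents on this carbon have all stayed within the scatter of one another. No measured evidence is available to explain why these swaps leave the read-out where it stands.

Methyl and chloro each bring a single heavy atom and no net charge, so it remains open whether a group such as an amine, a carboxylic acid or a longer chain on this same carbon would give a step beyond the scatter in this assay. On these data alone, it also remains open whether this lack of change would hold if the same swaps were made on other carbons of the shared core.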